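The source may report more compounds than this note shows. Statements on the series, on what has been measured and on what is new or still open speak of the compounds shown alone.

Measured compounds:
Compound 1, `C/C(=N\O)c1ccc(OCc2ccc(C(=O)NO)cc2)cc1`: in a functional assay on HepG2 cells (Homo sapiens) for antiproliferative activity, read by CCK-8 assay, with a stated time of 72 h (on this read-out higher numbers stand for weaker inhibition and lower numbers for stronger inhibition), compound 1 gives 7770 nM.
Compound 2, `Nc1ccccc1NC(=O)c1ccc(COc2ccc(Cl)cc2)cc1`: in this assay compound 2 gives > 32000 nM.

Compound 1 is the only one of the two with a plain number. For compound 2 the assay reports only a limit, not a number, so its activity is known just as lying on one side of that boundary. That boundary is the limit of > 32000 nM in this assay, at which 1 of the 2 values shown sits. Going by the values given here, compound 2 therefore stands at the weak end of what this assay can report, and no step between two measured compounds that differ in one place is available to guide a prediction.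

Compound 3, `Cc1ccc(OCc2ccc(C(=O)Nc3ccccc3N)cc2)cc1`, differs from compound 2 by methyl in place of chloro on an aromatic carbon. The swap exchanges one small group for another of the same size at the same place, with nothing gained or lost in donors, acceptors or charge. From compound 2 to compound 3 the step is expected to be a number no higher from compound 2 to compound 3 (the limit leaves the size open), that is, no change beyond the usual scatter. Compound 3 is estimated at 32000 nM, with a range from 12000 nM to 90000 nM, and it may well again come back only as a limit.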

Compound 3, half-maximal inhibitory concentration: 6590 nM
Compound 3: middle estimate off by 4.9-fold (0.69 log units), on the high side; measured number below the stated range.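

In this assay, the change from 4-chlorophenyl to 4-methylphenyl is not a neutral swap at this position, as it gives an at least 4.8-fold lower number from compound 2 to compound 3 (0.68 log units; beyond the scatter). Exchanging one heavy atom for another on an aromatic carbon para to a large group, with no hydrogen-bond donor, hydrogen-bond acceptor or net charge gained or lost, is enough to change the kind of result obtained. Compound 2 is reported only as a limit. Compound 3 gives 6590 nM, a plain number. The full size of the step stays unknown because compound 2 is reported only as a limit, not as a number: the limit of > 32000 nM in this assay, at which 1 of the 3 values shown sits.

This single pair cannot show whether methyl is special here or whether other groups at the same place, such as an amine, a methoxy group or a longer chain like ethyl, would give a similar number or a different one. From the compounds shown here alone, whether the same exchange would matter in a compound built like compound 1, which differs from compound 2 and compound 3 in more than one place, also remains open.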